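Amide to Sulfonamide on a Shorter Linker

This account rests on a few compounds, and the source may have more. Where it says the series, first, only, none or still open, it means among the compounds named here.

Compound 3 `O=C(NCCCNc1nccc(-c2c(-c3cccc(F)c3)nc3sccn23)n1)c1ccc(Cl)cc1` is known in potency only as a limit. In a functional assay on SK-MEL-28 cells (Homo sapiens) for cytotoxicity, read by MTT assay (a higher number here means a weaker inhibitor, a lower number a stronger inhibitor), compound 3 gives > 20000 nM, which is a limit of the assay rather than a number. Compound 1 `O=C(NCCCNc1nccc(-c2c(-c3cccc(F)c3)nc3sccn23)n1)c1ccc(F)cc1` gives > 20000 nM in this assay, again a limit. The step that the two limits leave unreadable from compound 1 to compound 3 therefore cannot be sized, because of the limit of > 20000 nM in this assay, at which 2 of the 3 values shown sit. For the measured compounds named here, compound 2 `O=C(NCCNc1nccc(-c2c(-c3cccc(F)c3)nc3sccn23)n1)c1ccc(C(F)(F)F)cc1` gives 9260 nM in this assay, the only number among the three compounds measured, and it is weak. Compound 4 `O=S(=O)(NCCNc1nccc(-c2c(-c3cccc(F)c3)nc3sccn23)n1)c1ccc(Cl)cc1` differs from compound 3 in that (((4-chlorophenyl)sulfonyl)amino in place of (((4-chlorophenyl)carbonyl)amino)methyl on a saturated chain carbon, two bonds along the chain from a nitrogen on an aromatic ring). Going by the values given here, no measured step follows this same change, and the single step that is known is unreadable, so the expectation rests on compound 3 being weak and on compound 2 being weak as well. Compound 4 is expected to show a step of an at least 1.3-fold lower number from compound 3 to compound 4 (0.12 log units; that floor lies within the scatter) that stays within the scatter. The estimate for compound 4 is 15000 nM, expected to fall between 5000 nM and 40000 nM.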

Compound 4, half-maximal inhibitory concentration: 18600 nM
Compound 4: the middle estimate sits 1.2-fold (0.09 log units) below what was measured; the measured number falls inside the stated range.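

In this assay, placing the ((4-chlorophenyl)sulfonyl)amino group at this position on the saturated chain gives an at least 1.0-fold lower number from compound 3 to compound 4 (0.03 log units; that floor lies within the scatter), and the same kind of change gives an at least 1.0-fold lower number from compound 1 to compound 4 (0.03 log units; that floor lies within the scatter). These two steps start from limits, so each gives only a floor, and neither can be sized: the limit of > 20000 nM in this assay, at which 2 of the 4 values shown sit. With real numbers at both ends, putting (4-chlorophenyl)sulfonyl in place of (4-(trifluoromethyl)phenyl)carbonyl on the amine nitrogen gives a 2.0-fold higher number from compound 2 to compound 4 (0.30 log units; within the scatter), so this change shows no effect that can be told from the usual scatter.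

The sulfonyl link has yet to be compared with a carbonyl link while the aromatic ring and the chain stay the same. On these data alone, it also remains open whether a free amine or a carboxylic acid at the end of the chain would move the number beyond the scatter.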